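This account rests on a few compounds, and the source may have more. Where it says the series, first, only, none or still open, it means among the compounds named here.

Measured in an ADME assay on HepG2 cells (Homo sapiens) for cytotoxicity, read by MTT assay, with a stated time of 48 h; a lower number here means a stronger inhibitor, a higher number a weaker inhibitor:
- Compound 1 `CS(=O)(=O)c1cccc(-c2ccc3ncnc(Nc4ccc(OCc5cccc(F)c5)c(Cl)c4)c3c2)c1`: > 15000 nM, a limit
- Compound 2 `Fc1cccc(COc2ccc(Nc3ncnc4ccc(-c5cccc(N6CCCCC6)c5)cc34)cc2Cl)c1`: > 15000 nM, a limit

Compound 2 has no exact number, and its reading of > 15000 nM is only a limit. The next structure, compound 3 `O=C(c1cccc(-c2ccc3ncnc(Nc4ccc(OCc5cccc(F)c5)c(Cl)c4)c3c2)c1)N1CCCCC1`, carries (piperidin-1-yl)carbonyl in place of piperidin-1-yl on an aromatic carbon. For the measured compounds named here, the only measured step bearing on this is a step that the two limits leave unreadable from compound 1 to compound 2, with piperidin-1-yl in place of methylsulfonyl on an aromatic carbon. It offers no size or direction to carry over. Compound 1 and compound 2 both sit at the limit of > 15000 nM in this assay, at which 2 of the 2 values shown sit, so the expectation is that this new change also leaves this assay without a clear shift. The estimated step is a step that the limit leaves unreadable from compound 2 to compound 3, which is none beyond the scatter. Compound 3 is expected at 18000 nM, within a range of 8000 nM to 40000 nM, and may well be reported as a limit again.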

Compound 3, half-maximal inhibitory concentration: > 6000 nM
Compound 3: no number, only a limit; the forecaster's own chance of this, stated with the estimate: 75%; the middle value lies beyond the limit too.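

Compound 1, compound 2 and compound 3 each carry only a limit in this assay, and the steps between them cannot be read. The compounds shown leave open whether methylsulfonyl, piperidin-1-yl and (piperidin-1-yl)carbonyl differ at all in their effect on these cells.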